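From cyclohexylamino to dipropylamino on a shared core

The source may report more compounds than this note shows. Statements on the series, on what has been measured and on what is new or still open speak of the compounds shown alone.

In a functional assay on HeLa cells (Homo sapiens) for inhibition, read by sulforhodamine B assay (a lower number here means a stronger inhibitor, a higher number a weaker inhibitor), compound 1 `CCCc1ccc(NC2=CC(=O)c3nc4n(c3C2=O)[C@H]2OC[C@@H](O)[C@H]2OC4)cc1` gives 4990 nM and compound 2 `CCc1ccc(NC2=CC(=O)c3c(nc4n3[C@H]3OC[C@@H](O)[C@H]3OC4)C2=O)cc1` gives 6510 nM. Compound 3 `O=C1C=C(NC2CCCCC2)C(=O)c2c1nc1n2[C@H]2OC[C@@H](O)[C@H]2OC1` reads > 16000 nM in this assay, and this is a limit of the assay, not a number. Compound 3 therefore has no exact place on the scale.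

Compound 4 `CCCN(CCC)C1=CC(=O)c2nc3n(c2C1=O)[C@H]1OC[C@@H](O)[C@H]1OC3` carries dipropylamino in place of cyclohexylamino on a double-bonded ring carbon. Going by the values given here, only one measured step touches this amine group: an at least 3.2-fold higher number from compound 1 to compound 3 (0.50 log units; beyond the scatter). That step lies beyond the scatter, but it ends at a limit, so it shows only the smallest size the change could have. Among the compounds with values here, no measured compound carries dipropylamino. Like the cyclohexylamino of compound 3, at > 16000 nM, the new group lacks the 4-propylphenyl of compound 1, so weak inhibition is expected to persist. The estimated step is a number no higher from compound 3 to compound 4 (the limit leaves the size open), and none beyond the scatter is expected. The expected value for compound 4 is 16000 nM, within an estimated range of 7000 nM to 40000 nM.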

Compound 4, half-maximal inhibitory concentration: > 16000 nM
Compound 4 ended at the assay's limit (the forecaster's own chance of this, stated with the estimate: 55%); the middle value lies on the limit itself.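

Compound 3 and compound 4 both end at a limit of the assay rather than at a number, so no step can be read between them: the limit of > 16000 nM in this assay, at which 2 of the 4 values shown sit.

The compounds shown leave open how strongly either compound inhibits in this assay, and whether dipropylamino differs from cyclohexylamino on the shared core.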